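Thiazole amine versus methyl, clearance in rat microsomes

The source may report more compounds than this note shows. Statements on the series, on what has been measured and on what is new or still open speak of the compounds shown alone.

Measured compounds and their values:
compound 1, `Nc1nc2c(s1)CC[C@H]2C(=O)Nc1ccc(C[C@@H]2CC[C@H]([C@H](O)c3ccccc3)N2)cc1`: 59 mL/min/kg
compound 2, `Cc1nc2c(s1)CC[C@H]2C(=O)Nc1ccc(C[C@@H]2CC[C@H]([C@H](O)c3cccnc3)N2)cc1`: 62 mL/min/kg

Both values come from an ADME assay (liver) for metabolic stability, with Liver microsome (Rattus norvegicus) as the target, using microsomes; a lower number here means slower removal, a higher number faster removal of the compound. Compound 2 gives the higher of the two numbers, but its gap to compound 1 lies within the scatter, so the two compounds cannot be told apart on these data.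

Compound 3, `Nc1nc2c(s1)CC[C@H]2C(=O)Nc1ccc(C[C@@H]2CC[C@H]([C@H](O)c3cccnc3)N2)cc1`, is not yet measured. It is derived from compound 2 by one change: amino in place of methyl on an aromatic carbon. Among the measured compounds shown here, compound 1 already carries the amino group that enters here, while it differs from compound 3 elsewhere, so no single step between measured compounds isolates this change.

Nothing in the two measured values points to a shift beyond the scatter for this change. Compound 2 and compound 1, which together already span the amino and the methyl at this position, give numbers that are indistinguishable in this assay. The step from compound 2 to compound 3 is therefore expected to be a 1.1-fold lower number from compound 2 to compound 3 (0.04 log units; within the scatter), that is, no change beyond the scatter. Compound 3 is estimated to give 57 mL/min/kg in this assay, with a range from 30 mL/min/kg to 105 mL/min/kg.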

Compound 3, clearance: 57 mL/min/kg
Compound 3: the middle estimate sits on the measured number at the digits printed, and the stated range covers the measured number.
By their numbers in this assay, from the lowest: compounds 3, 1 and 2 (each within the scatter of the next).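

With the pyridin-3-yl side held constant, amino in place of methyl on the aromatic carbon of the five-membered aromatic ring can now be read on its own in this assay: the step is a 1.1-fold lower number from compound 2 to compound 3 (0.04 log units; within the scatter) and does not separate the two groups at this position. With the amino group held constant, pyridin-3-yl in place of phenyl can also be read on its own, as a 1.0-fold lower number from compound 1 to compound 3 (0.01 log units; within the scatter), so the match between compound 1 and compound 2 does not rest on two large single-place steps offsetting each other. No measurement shown offers an explanation for either step.

Only amino and methyl have been compared at this aromatic carbon, on the pyridin-3-yl background, so a hydrogen, a longer chain such as ethyl, or a carboxylic acid there could give a different reading. The methyl group paired with phenyl is also absent from the compounds shown, which leaves the amino-for-methyl step untested on the phenyl background.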